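Swapping a Furan Amide for an Indole Amide

The compounds below may be only part of what the source reports. "The series", "measured", "known", "first", "only" and "open" are said of these compounds alone.

In an assay on isolated protein for inhibition of sodium channel protein type 3 subunit alpha (Homo sapiens), read by electrophysiology, with a stated time of 4 min (a lower number here means a stronger inhibitor, a higher number a weaker inhibitor), compound 2 `CNc1nc(-c2cccc(NC(=O)c3ccco3)c2)cn1C(=O)OC(C)(C)C` gives only a limit, > 30000 nM, not a number. That value sits at the limit of > 30000 nM in this assay, at which 1 of the 2 values shown sits. Compound 1 `CC(C)(C)OC(=O)n1cc(-c2cccc(NC(=O)c3cc4ccccc4[nH]3)c2)nc1N`, which carries an indole amide, gives 26000 nM in this assay, a number rather than a limit. Compound 3 `CNc1nc(-c2cccc(NC(=O)c3cc4ccccc4[nH]3)c2)cn1C(=O)OC(C)(C)C` is reached from compound 2 by a single change: 1H-indol-2-yl in place of furan-2-yl on a carbonyl carbon. Among the compounds with values here, no measured pair shows this change alone, so its size is uncertain. Compound 3 is nevertheless expected to come out a little stronger than that limit, a step of an at least 1.3-fold lower number from compound 2 to compound 3 (0.13 log units; that floor lies within the scatter). For compound 3 the estimate is 22000 nM, with a range from 7000 nM to 60000 nM.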

Compound 3, half-maximal inhibitory concentration: > 30000 nM
Compound 3: only a limit was reported (the forecaster's own chance of this, stated with the estimate: 40%); at least 1.3-fold (0.13 log units) between middle value and limit.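

In this assay both compound 2 and compound 3 end in limits, so the step between them cannot be read, and the indole amide shows no readable gain over the furan amide on this carbonyl carbon. Methyl in place of hydrogen on a nitrogen on an aromatic ring gives an at least 1.1-fold higher number from compound 1 to compound 3 (0.06 log units; that floor lies within the scatter), so that change is not shown to matter in either direction. Most of the compounds now stop at one limit: the limit of > 30000 nM in this assay, at which 2 of the 3 values shown sit.

From the compounds shown here alone, it remains open whether a phenyl ring or a longer chain on this carbonyl carbon would give a number rather than a limit. Going by these compounds, whether a free amine on the ring nitrogen, in place of the tert-butyl carbamate, would do so also remains open.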